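A few compounds are considered here, and "the series" means these few. Any claim that something is new, unique, unknown or untested is made for them only; others in the source may bear on it.

Compound 3 `ClCc1ccc(Cn2cnc3ncnc(Cl)c32)cc1` gives 2750 nM in a functional assay on M14 cells (Homo sapiens) for cytotoxicity, read by sulforhodamine B assay, with a stated time of 48 h (on this read-out higher numbers stand for weaker inhibition of growth and lower numbers for stronger inhibition of growth), the second highest of the three numbers; compound 2 `ClCc1ccccc1Cn1cnc2c(Cl)ncnc21`, at 1950 nM, lies within the scatter of it, while compound 1 `Nc1nc(Cl)c2ncn(Cc3ccccc3CCl)c2n1`, at 5750 nM, sits beyond it. Compound 4 `ClCc1ccc(Cn2cnc3nc(Cl)nc(Cl)c32)cc1` carries chloro in place of hydrogen on an aromatic carbon, on the carbon between two ring nitrogen atoms. Among the compounds with values here, the only measured step at that site is a 2.9-fold lower number from compound 1 to compound 2 (0.47 log units; beyond the scatter); it concerns a different group, so it gives no direct precedent for the entering chloro, and a step no larger than the scatter, or at most a modest lowering of the number, is expected in this assay. The estimate for compound 4 is 2000 nM, from 800 nM to 5000 nM, meaning a 1.4-fold lower number from compound 3 to compound 4 (0.14 log units; within the scatter).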

Compound 4, concentration for 50% growth inhibition: 1440 nM
Estimate against measurement, compound 4: 1.4-fold (0.14 log units) above; the measured number falls inside the stated range.
By their numbers in this assay, from the lowest: compounds 4, 2 and 3 (each within the scatter of the next); then compound 1.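

In this assay chloro in place of hydrogen on the carbon between two ring nitrogen atoms gives a step that stays within the scatter (a 1.9-fold lower number from compound 3 to compound 4 (0.28 log units; within the scatter)), so this carbon carries a chloro group with no clear change in the number. The earlier step at this carbon (a 2.9-fold lower number from compound 1 to compound 2 (0.47 log units; beyond the scatter)) concerned amino in another pair of compounds and gave no reading for chloro. No measurement explains the small step.

As far as these compounds go, whether methyl or methoxy at this carbon would stay within the scatter remains open. So does the effect of chloro here on the core of compound 2.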